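This account rests on a few compounds, and the source may have more. Where it says the series, first, only, none or still open, it means among the compounds named here.

In an ADME assay on HeLa cells (Homo sapiens) for cytotoxicity, read by sulforhodamine B assay, with a stated time of 48 h, tested at 10 uM (a higher number here means more inhibition at the concentration tested (going by the name of the read-out), a lower number less inhibition), the three measured compounds gave these numbers:

compound 1, `COc1nc2ccc(Br)cc2cc1C(c1ccccc1)n1cc(-c2ccccc2)nn1`: 13.9%
compound 2, `CCCCCc1cn(C(c2ccccc2)c2cc3cc(Br)ccc3nc2OC)nn1`: -9.81%
compound 3, `COc1nc2ccc(Br)cc2cc1C(c1ccccc1)n1cc(CCCO)nn1`: 11.3%

Compound 3 stands second highest of the three numbers. Its nearest neighbour is compound 1, and the two differ only within the scatter, as the step of a number 2.6 percentage points lower from compound 1 to compound 3 (within the scatter) shows. The step of a number 21.1 percentage points higher from compound 2 to compound 3 (beyond the scatter) is the one that lies beyond the scatter, with compound 2 at the low end.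

Compound 4, `COc1nc2ccc(Br)cc2cc1C(c1ccccc1)n1cc(CCCCCO)nn1`, has not been measured. It differs from compound 3 in one place: 2-hydroxyethyl in place of hydroxy on a saturated chain carbon, three bonds along the chain from an aromatic carbon. The chain therefore grows longer while the hydroxy group stays at its end.

For the measured compounds named here, two measured steps bear on this. The step of a number 2.6 percentage points lower from compound 1 to compound 3 (within the scatter) shows that a 3-hydroxypropyl chain and a phenyl give numbers within the scatter of each other. The step of a number 21.1 percentage points higher from compound 2 to compound 3 (beyond the scatter) shows that a plain pentyl chain without a hydroxy group sits clearly lower. Compound 4 keeps the hydroxy group but gains chain, so a small move downward is expected, most likely within the scatter: a number 5.3 percentage points lower from compound 3 to compound 4 (within the scatter).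

Compound 4 is therefore estimated at 6% in this assay, with a range from -10% to 20%.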

Compound 4, a percentage reported as inhibition, at one concentration (the size of the read-out at that concentration, not a potency): 1.08%
The estimate for compound 4 lay 4.9 percentage points above the measured number, and the stated range covers the measured number.
By their numbers in this assay, from the lowest: compound 2; then compound 4; then compounds 3 and 1 (each within the scatter of the next).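

Lengthening the chain from 3-hydroxypropyl to 5-hydroxypentyl, with the hydroxy kept at its end, gives a number 10.2 percentage points lower from compound 3 to compound 4 (beyond the scatter) in this assay and so shows that chain length counts at this position even when the hydroxy stays in place. The hydroxy also still counts on the longer chain, with a number 10.9 percentage points higher from compound 2 to compound 4 (beyond the scatter) when it is added to the end of the pentyl group, and the 5-hydroxypentyl chain separates from phenyl, with a number 12.8 percentage points lower from compound 1 to compound 4 (beyond the scatter) for that exchange, which the 3-hydroxypropyl chain did not do. Nothing available here explains why either change moves the number, so these results describe what happens at this position and not the reason for it.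

The compounds shown leave open whether the number falls evenly with chain length, which a 4-hydroxybutyl chain would help to settle, and whether it keeps falling with a still longer chain that ends in hydroxy. They also leave open whether an amine or a carboxylic acid at the end of the chain would behave as the hydroxy does, or whether only the hydroxy gives this result.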